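The compounds below may be only part of what the source reports. "The series", "measured", "known", "first", "only" and "open" are said of these compounds alone.

Compound 1, `CC(C)=Cc1c(-c2ccccc2)sc(C(C)C)c1/C=C/[C@@H](O)C[C@@H](O)CC(=O)O`, gives 1000 nM in an assay on microsomes for inhibition of 3-hydroxy-3-methylglutaryl-coenzyme A reductase (Rattus norvegicus); a lower number here means a stronger inhibitor, a higher number a weaker inhibitor.
Compound 2, `CC(C)c1sc(-c2ccccc2)c(C2CCCCC2)c1/C=C/[C@@H](O)C[C@@H](O)CC(=O)O`, gives 202 nM in this assay.
Compound 3, `CC(C)c1sc(-c2ccccc2)c(-c2ccc(F)cc2)c1/C=C/[C@@H](O)C[C@@H](O)CC(=O)O`, gives 4.4 nM in this assay.

Compound 3 stands lowest of the three numbers; its nearest neighbour is compound 2, a 46-fold lower number from compound 2 to compound 3 (1.66 log units; beyond the scatter), and the furthest is compound 1, a 230-fold lower number from compound 1 to compound 3 (2.36 log units; beyond the scatter). Compound 4, `CC(C)c1sc(-c2ccccc2)c(-c2cccs2)c1/C=C/[C@@H](O)C[C@@H](O)CC(=O)O`, differs from compound 3 in one place: thiophen-2-yl in place of 4-fluorophenyl on an aromatic carbon. Going by the values given here, no measured step exchanges one aromatic ring for another at this position. Among the compounds with values here, the steps that bear on it are a 46-fold lower number from compound 2 to compound 3 (1.66 log units; beyond the scatter) and a 230-fold lower number from compound 1 to compound 3 (2.36 log units; beyond the scatter), both large, and both show that an aromatic ring at this carbon gives far lower numbers than a cyclohexyl or a 2-methylprop-1-en-1-yl group. Since the thiophen-2-yl group keeps an aromatic ring there, compound 4 is expected to remain close to compound 3, with at most a modest rise in this assay, a 1.8-fold higher number from compound 3 to compound 4 (0.26 log units; within the scatter). Compound 4 is therefore estimated at 8 nM, within a range of 2.5 nM to 30 nM.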

Compound 4, half-maximal inhibitory concentration: 1420 nM
Estimate against measurement, compound 4: 180-fold (2.25 log units) below, and the stated range ends below it.
By their numbers in this assay, from the lowest: compound 3; then compound 2; then compounds 1 and 4 (each within the scatter of the next).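

At this carbon, an aromatic ring alone does not secure a low number in this assay: thiophen-2-yl in place of 4-fluorophenyl gives a large loss (a 320-fold higher number from compound 3 to compound 4 (2.51 log units; beyond the scatter)). The earlier contrast with the non-aromatic groups therefore holds for 4-fluorophenyl but does not extend to this five-membered aromatic ring, which falls on the weaker side of cyclohexyl (a 7.0-fold higher number from compound 2 to compound 4 (0.85 log units; beyond the scatter)) and cannot be separated from 2-methylprop-1-en-1-yl (a 1.4-fold higher number from compound 1 to compound 4 (0.15 log units; within the scatter)). Nothing measured here accounts for this gap.

The compounds shown leave open whether the rise goes with the loss of the fluorine, the smaller ring or the ring sulfur. A plain phenyl, a furan-2-yl or a thiophen-3-yl group at this carbon would help to separate these changes.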